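Swapping a Sulfur Substituent in Two Related Series

The source may report more compounds than this note shows. Statements on the series, on what has been measured and on what is new or still open speak of the compounds shown alone.

Compound 1 `Cc1ccc(S/C(=C/c2ccc(Cl)cc2)C(=O)c2ccc(Br)cc2)cc1` and compound 2 `O=C(/C(=C\c1ccc(Cl)cc1)SCc1ccc(Cl)cc1)c1ccc(Br)cc1` share one core, while compound 3 `COc1cc(OC)c(/C=C(\C(=O)c2ccc(Br)cc2)S(=O)(=O)Cc2ccc(Cl)cc2)c(OC)c1` is built on another; the difference between the two cores is not broken down here. In a functional assay on DU-145 cells (Homo sapiens) for inhibition, read by trypan blue exclusion, with a stated time of 96 h (on this read-out lower numbers stand for stronger inhibition of growth and higher numbers for weaker inhibition of growth), compound 1 gives 10000 nM and compound 2 gives 10000 nM. The change between them, (4-methylphenyl in place of 4-chlorobenzyl on a sulfur), made the step of no change at the digits printed from compound 2 to compound 1 (within the scatter). In this assay compound 3 gives 25000 nM. Compound 4 `COc1cc(OC)c(/C=C(\C(=O)c2ccc(Br)cc2)S(=O)(=O)c2ccc(C)cc2)c(OC)c1` arises from compound 3 through (4-methylphenyl in place of 4-chlorobenzyl on a sulfonyl sulfur), the same kind of change, though here the place is a sulfonyl sulfur rather than a sulfur. Because no change at the digits printed from compound 2 to compound 1 (within the scatter) lay within the scatter, the expected step is no change at the digits printed from compound 3 to compound 4 (within the scatter). Compound 4 is therefore estimated at 25000 nM in this assay, with a likely range from 12000 nM to 50000 nM.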

Compound 4, concentration for 50% growth inhibition: > 100000 nM
Compound 4: a limit, no number (the forecaster's own chance of this, stated with the estimate: 15%); middle value at least 4.0-fold (0.60 log units) from the limit.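

In this assay the change on the sulfonyl sulfur gives an at least 4.0-fold higher number from compound 3 to compound 4 (0.60 log units; beyond the scatter), which does not match the step seen on the other core: the same change on two cores in this assay, no change at the digits printed (within the scatter) from compound 2 to compound 1 and an at least 4.0-fold higher number (0.60 log units; beyond the scatter) from compound 3 to compound 4, at least 4.0-fold (0.60 log units) apart, beyond the scatter of two such steps

Compound 4 gives > 100000 nM, which is a limit of the assay and not a number: the limit of > 100000 nM in this assay, at which 1 of the 4 values shown sits.

For the compounds shown here, with only one pair on each core, this shows that the step seen on one core cannot simply be assumed for the other, but it does not show why the two steps differ or how large the second step truly is.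

Still open, from the compounds shown here alone, is whether the sulfonyl sulfur itself or some other part of the core matters. Going by these compounds, it is also open how a longer chain or an amine placed on the sulfonyl sulfur would read in this assay.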